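Fluoro to trifluoromethyl: cytotoxicity notes on the series

The source may hold more compounds than are shown below. What is called first, only, known or untested is meant among the compounds shown, and "the series" means these compounds.

Measured so far:
- compound 1 `CC(C)N(Cc1cccc(OCCCCCC(=O)O)c1)C(=O)c1ccc(-c2cccc(OC(F)(F)F)c2)cc1`; in an ADME assay on Raji cells (Homo sapiens) for cytotoxicity, read by CellTiter-Glo and resazurin assay, with a stated time of 72 h (a lower number here means that less compound is needed, a higher number that more compound is needed for the effect), compound 1 gives > 26000 nM, which is a limit of the assay.
- compound 2 `CC(C)N(Cc1cccc(OCCCCCC(=O)O)c1)C(=O)c1ccc(-c2cccc(F)c2)cc1`; in this assay compound 2 gives > 26000 nM, also a limit of the assay.

Compound 2 stands only on a limit in this assay; no number is known for it. Within the data shown here, the one measured step, a step that the two limits leave unreadable from compound 1 to compound 2, is unreadable, since both of its ends sit at the limit of > 26000 nM in this assay, at which 2 of the 2 values shown sit.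

The next compound is compound 3 `CC(C)N(Cc1cccc(OCCCCCC(=O)O)c1)C(=O)c1ccc(-c2cccc(C(F)(F)F)c2)cc1`. It differs from compound 2 by trifluoromethyl in place of fluoro on an aromatic carbon. Among the measured compounds shown here, no measured step bears on this change: the single step between compounds 1 and 2 concerns the trifluoromethoxy and fluoro groups and gives no readable size. Nothing among the shown values points to a direction.

Given that both measured compounds sit at the limit of > 26000 nM in this assay, at which 2 of the 2 values shown sit, compound 3 is expected to sit at the limit as well, with an estimated step that the limit leaves unreadable from compound 2 to compound 3 from compound 2 to compound 3. The estimate for compound 3 in this assay is therefore 40000 nM, expected between 15000 nM and 120000 nM.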

Compound 3, half-maximal effective concentration: > 26000 nM
Compound 3: only a limit was reported (the forecaster's own chance of this, stated with the estimate: 80%); the middle value is on the limit's open side.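

Among these compounds, with compound 3 also reported only as a limit, no step among compound 1, compound 2 and compound 3 can be read in this assay: the limit of > 26000 nM in this assay, at which 3 of the 3 values shown sit.

The compounds shown leave open where the true values of these three lie, and whether any group on that aromatic carbon would give a measured number instead of a limit.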